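Heptyl to (4-methoxyphenyl)carbamoyl swap on the shared core

The source may hold more compounds than are shown below. What is called first, only, known or untested is meant among the compounds shown, and "the series" means these compounds.

Compound 1 `O=C(O)C1=Cc2ccccc2OC1(OCc1cc(-c2ccc(F)cc2F)no1)C(F)(F)F`, compound 2 `CCCCCCCCn1cc(COC2(C(F)(F)F)Oc3ccccc3C=C2C(=O)OCC)nn1` and compound 3 `CCOC(=O)C1=Cc2ccccc2OC1(OCc1cc(-c2ccc(C)cc2)no1)C(F)(F)F` share one core and were tested in a functional assay on MCF7 cells (Homo sapiens) for inhibition, read by MTT assay, with a stated time of 24 h; a lower number here means a stronger inhibitor, a higher number a weaker inhibitor. Compound 1 returns only the limit of the assay, > 150000 nM, not a number. Compound 2 likewise sits at the limit, > 150000 nM. Compound 3 also gives only the limit, > 150000 nM. Going by the values given here, compound 2 therefore stands nowhere on a scale: every value shown is the same limit (the limit of > 150000 nM in this assay, at which 3 of the 3 values shown sit), and no step between measured compounds can be read off.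

Compound 4 `CCOC(=O)C1=Cc2ccccc2OC1(OCc1cn(CC(=O)Nc2ccc(OC)cc2)nn1)C(F)(F)F` remains to be measured in this assay. It differs from compound 2 by (4-methoxyphenyl)carbamoyl in place of heptyl on a saturated chain carbon bound to an aromatic nitrogen. With all shown values at the limit there is no measured step from which a size or direction could be taken; the expected step is none beyond the scatter, a number no higher from compound 2 to compound 4 (the limit leaves the size open), and compound 4 is expected most likely to return the limit again. The estimate for compound 4 is 150000 nM, expected to lie between 50000 nM and 300000 nM.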

Compound 4, half-maximal inhibitory concentration: 28100 nM
Compound 4: the middle estimate sits 5.3-fold (0.73 log units) above what was measured; the measured number lies below the stated range.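

On the saturated chain carbon bound to an aromatic nitrogen, (4-methoxyphenyl)carbamoyl in place of heptyl gives an at least 5.3-fold lower number from compound 2 to compound 4 (0.72 log units; beyond the scatter) in this assay, so this position can respond to a change in the group it carries. On these data alone, compound 2 gives > 150000 nM, which is a limit of the assay and not a number, so the full size of the step stays open. Compound 4 is the only compound shown that gives a number rather than the limit: the limit of > 150000 nM in this assay, at which 3 of the 4 values shown sit.

The compounds shown do not separate the contributions of the amide carbonyl, the amide hydrogen, the aromatic ring and the methoxy group to this step. An unsubstituted phenylcarbamoyl, a benzyl group, a carboxylic acid or an amine on the same carbon would help to separate them.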